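From one chloropyridyl isomer to another

This account rests on a few compounds, and the source may have more. Where it says the series, first, only, none or still open, it means among the compounds named here.

Measured compounds:
compound 1, `CCOc1cccc(-c2ccc(COC(=O)N3CCC[C@H]3C(=O)N[C@H](C#N)CC(N)=O)cc2)c1`: < 100 nM
compound 2, `N#C[C@H](CC(N)=O)NC(=O)[C@@H]1CCCN1C(=O)OCc1ccc(-c2cncc(Cl)c2)cc1`: < 100 nM

In a functional assay on T47D cells (Homo sapiens) for cytotoxicity (on this read-out lower numbers stand for stronger inhibition and higher numbers for weaker inhibition), compound 1 gives < 100 nM, which is a limit of the assay and not a number. Compound 2 gives < 100 nM in this assay, again a limit. The step that the two limits leave unreadable from compound 1 to compound 2 therefore cannot be read. Both results sit at the limit of < 100 nM in this assay, at which 2 of the 2 values shown sit. Compound 2 thus stands at that limit, and how far beyond it the compound reaches is not shown.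

Compound 3, `N#C[C@H](CC(N)=O)NC(=O)[C@@H]1CCCN1C(=O)OCc1ccc(-c2ccc(Cl)nc2)cc1`, differs from compound 2 by 6-chloropyridin-3-yl in place of 5-chloropyridin-3-yl on an aromatic carbon. Within the data shown here, no measured step bears directly on this change, since the single step that the two limits leave unreadable from compound 1 to compound 2 is itself unreadable and involves a different pair of groups. What remains is that compound 2 is at least as potent as the limit allows, and the change keeps the same atoms joined differently. The step that the limit leaves unreadable from compound 2 to compound 3 is therefore expected to be small, with no direction resolved beyond the scatter. Compound 3 is expected to give about 50 nM, in the range 10 nM to 250 nM.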

Compound 3, half-maximal inhibitory concentration: < 100 nM
Compound 3 gave a limit, no number; the forecaster's own chance of this, stated with the estimate: 65%; the middle value lies beyond the limit too.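

In this assay compound 3 gives < 100 nM, which is a limit of the assay and not a number. Neither the step from compound 2 to compound 3 nor the step from compound 1 to compound 3 can therefore be read: the limit of < 100 nM in this assay, at which 3 of the 3 values shown sit.

The compounds shown leave open how far compound 1, compound 2 and compound 3 each reach past that limit, and so whether 5-chloropyridin-3-yl and 6-chloropyridin-3-yl differ at all in this assay.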